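A few compounds are considered here, and "the series" means these few. Any claim that something is new, unique, unknown or untested is made for them only; others in the source may bear on it.

Measured compounds:
- compound 1, `Cc1noc(NS(=O)(=O)c2ccc(NCc3ccccc3)cc2)c1C`, with 9800 nM in an assay on VSM-A10 cells for antagonist activity at Endothelin-1 receptor (Rattus norvegicus); on this read-out higher numbers stand for weaker inhibition and lower numbers for stronger inhibition
- compound 2, `CCCCCNc1cccc2c(S(=O)(=O)Nc3onc(C)c3C)cccc12`, with 80 nM in this assay

Compound 2 gives the lowest of the two numbers seen here. Its nearest neighbour is compound 1, whose value is far higher, a gap that lies beyond the usual scatter of repeated measurements. Since the two structures differ in more than one place, nothing can be said about which part of the difference drives that gap; only the two values themselves are known.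

Compound 3, `Cc1noc(NS(=O)(=O)c2cccc3c(N4CCCCC4=O)cccc23)c1C`, has not yet been measured. It is derived from compound 2 by a single change: 2-oxopiperidin-1-yl in place of pentylamino on an aromatic carbon. The open chain with its hydrogen-bond donor is thus traded for a ring that carries an acceptor but no donor. Among the compounds with values here, no measured pair here isolates such a swap, so the size and direction of its effect are unknown. In this assay a modest loss of potency is expected for compound 3, corresponding to an estimated step of a 3.8-fold higher number from compound 2 to compound 3 (0.57 log units; beyond the scatter). The estimated value for compound 3 is 300 nM, with a range from 60 nM to 2000 nM.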

Compound 3, half-maximal inhibitory concentration: 270 nM
Beside the measured number, compound 3's estimate is 1.1-fold (0.05 log units) above it; low and high end bracket the measured number.
By their numbers in this assay, from the lowest: compound 2; then compound 3; then compound 1.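

In this assay, putting 2-oxopiperidin-1-yl in place of pentylamino on this aromatic carbon gives a 3.4-fold higher number from compound 2 to compound 3 (0.53 log units; beyond the scatter). This is the first pair shown that differs in one place, and it reveals that the group on this carbon does affect the read-out, although this swap costs only a modest amount of potency rather than abolishing inhibition. The swap removes the hydrogen-bond donor, closes the open chain into a six-membered non-aromatic ring and adds a carbonyl all at once, and no measurement here ties the step to any one of these features or explains it.

The compounds shown leave open which of these features accounts for the step, since a piperidin-1-yl group, which keeps the ring but has no carbonyl, or a longer chain such as hexylamino, which keeps the donor, would each separate them. Going by these compounds, it also remains open whether the same swap would have a similar effect on a different core, such as that of compound 1, which carries a benzylamino group instead.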